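Oxetane Replaces Amide Chain on the Alkyne of Compound 2

The source may report more compounds than this note shows. Statements on the series, on what has been measured and on what is new or still open speak of the compounds shown alone.

Compound 1 `CC(O)CC#Cc1c(Cl)c2c(Cl)cc(C(N)=O)nc2n1[C@H]1CCCNC1`: 48 nM
Compound 2 `CC(C)(CC#Cc1c(Cl)c2c(Cl)cc(C(N)=O)nc2n1[C@H]1CCCNC1)C(N)=O`: 269 nM
Compound 3 `NC(=O)c1cc(Cl)c2c(Cl)c(C#CC3CNCCO3)n([C@H]3CCCNC3)c2n1`: 365 nM; 197 nM (2 entries)

Three compounds share one core and differ only in the group attached to the triple bond. In a functional assay on KG-1 cells (Homo sapiens) for antiproliferative activity (on this read-out higher numbers stand for an effect only at larger amounts of compound and lower numbers for an effect already at smaller amounts), compound 1 gives the lower single number, and compound 2 stands as the higher of the two, the step being a 5.6-fold higher number from compound 1 to compound 2 (0.75 log units; beyond the scatter). Compound 3, carrying a ring directly on the triple-bonded carbon, gives two entries the several entries of compound 3 in this assay, 365 nM; 197 nM (2 entries) that lie in the same region as compound 2.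

Compound 4 `CC1(C#Cc2c(Cl)c3c(Cl)cc(C(N)=O)nc3n2[C@H]2CCCNC2)COC1` is the next variation: 3-methyloxetan-3-yl in place of 2-carbamoyl-2-methylpropyl on a triple-bonded carbon. Among the measured compounds shown here, only one measured step touches this position, a 5.6-fold higher number from compound 1 to compound 2 (0.75 log units; beyond the scatter), and it shows that swapping the group on the chain changes the number only modestly. The two entries of compound 3 show that a small saturated ring placed directly on the triple-bonded carbon also lands near compound 2. The expected change is therefore small, with a slight lean towards a lower number, and may stay within the scatter; the expected step is a 1.7-fold lower number from compound 2 to compound 4 (0.23 log units; within the scatter). Compound 4 is estimated at 160 nM, within 50 nM to 500 nM.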

Compound 4, half-maximal effective concentration: 119 nM
For compound 4 the middle estimate is 1.3-fold (0.13 log units) above the measured one; measured number inside the range.
By their numbers in this assay, from the lowest: compound 1; then compound 4; then compound 2.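

In this assay, a 2.3-fold lower number from compound 2 to compound 4 (0.35 log units; beyond the scatter) shows that the carbamoyl group of the 2-carbamoyl-2-methylpropyl chain need not be kept at this place: a small ring set directly on the triple-bonded carbon gives a lower number without it. That ring does not match the open chain with the hydroxyl, though, since a 2.5-fold higher number from compound 1 to compound 4 (0.39 log units; beyond the scatter) leaves compound 1 with the lowest single number of the three. Compound 3 also carries a ring directly on the triple-bonded carbon, so any reading of ring type here must allow for the spread in: the several entries of compound 3 in this assay, 365 nM; 197 nM (2 entries)

Because the swap changes the ring and removes the carbamoyl group together, the compounds shown do not separate these two changes. As far as these compounds go, how a plain cyclobutyl ring, or a 3-aminooxetan-3-yl group with an amine in place of the methyl, would read remains open.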